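This account rests on a few compounds, and the source may have more. Where it says the series, first, only, none or still open, it means among the compounds named here.

In an assay on cells for inhibition of HSP60/HSP10 (Homo sapiens), with a stated time of 60 min (on this read-out higher numbers stand for weaker inhibition and lower numbers for stronger inhibition), compound 1 `O=S(=O)(Nc1ccc2oc(-c3ccccc3)nc2c1)c1cccc(C(F)(F)F)c1` reaches only the limit of the assay, > 100000 nM. Compound 2 `Cc1cccc(S(=O)(=O)Nc2ccc3oc(-c4ccccc4)nc3c2)c1` likewise stops at the assay limit, giving > 100000 nM. Within the data shown here, the single change between the two, a step that the two limits leave unreadable from compound 1 to compound 2, cannot be sized: the limit of > 100000 nM in this assay, at which 2 of the 2 values shown sit, records that both values sit at the limit. Compound 2 therefore stands at the ceiling of the numbers shown, with no measurable inhibition.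

Compound 3 `CS(=O)(=O)Nc1ccc2oc(-c3ccccc3)nc2c1` has not been measured. It keeps the shared core of compound 2 and alters one group: methyl in place of 3-methylphenyl on a sulfonyl sulfur. The aromatic portion of the sulfonamide is thus exchanged for a single methyl.

Among the measured compounds shown here, only one measured step bears on this change, and it is the unreadable one; it shows that trading trifluoromethyl for methyl on the aromatic carbon left both compounds at the limit. For the measured compounds named here, no step on the sulfonyl sulfur itself has been measured. The expected outcome for compound 3 in this assay is therefore no readable step, a step that the limit leaves unreadable from compound 2 to compound 3, with a limit again the likeliest report. Compound 3 is estimated at 200000 nM, within 50000 nM to 1000000 nM.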

Compound 3, half-maximal inhibitory concentration: > 100000 nM
Compound 3 was reported as a limit (the forecaster's own chance of this, stated with the estimate: 85%); the middle value does not contradict the limit.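

The step from compound 2 to compound 3 cannot be read, since both report only a limit in this assay: the limit of > 100000 nM in this assay, at which 3 of the 3 values shown sit.

The compounds shown leave open whether any group on the sulfonyl sulfur can give a true number in this assay, and how the three compounds would rank if they could be told apart.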